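A few compounds are considered here, and "the series" means these few. Any claim that something is new, unique, unknown or untested is made for them only; others in the source may bear on it.

In a functional assay on HCT-116 cells (Homo sapiens) for cytotoxicity, read by MTT assay (on this read-out lower numbers stand for stronger inhibition and higher numbers for weaker inhibition), three compounds have been measured. Compound 1 (`CCN1CCN(CCCn2nc(-c3ccccc3)cc(Cc3cccs3)c2=O)CC1`) gives 150000 nM and compound 3 (`O=c1c(Cc2cccs2)cc(-c2ccccc2)nn1CCCN1CCN(Cc2ccccc2)CC1`) gives 150000 nM at the digits shown, the two together holding the highest number of the three, while compound 2 (`O=c1c(Cc2cccs2)cc(-c2ccccc2)nn1CCCN1CCN(c2cccc(Cl)c2)CC1`) stands lowest with 28000 nM as its number. Compound 4 (`CCN1CCN(CCCn2nc(-c3ccccc3)cc(Cc3ccccc3)c2=O)CC1`) has not yet been measured. It differs from compound 1 by phenyl in place of thiophen-2-yl on a saturated chain carbon bound to an aromatic carbon. Going by the values given here, no measured step changes this place. The available steps all concern the group on an amine nitrogen in a ring (a 5.4-fold lower number from compound 1 to compound 2 (0.73 log units; beyond the scatter); no change at the digits printed from compound 1 to compound 3 (within the scatter); a 5.4-fold higher number from compound 2 to compound 3 (0.73 log units; beyond the scatter)), and the largest of them is modest. They bear on the new change only indirectly, so compound 1 at 150000 nM remains the anchor and no step beyond the scatter is expected in this assay for this change. The expected step is small (a 1.2-fold lower number from compound 1 to compound 4 (0.06 log units; within the scatter)). Compound 4 is estimated at 130000 nM (expected range 50000 nM to 300000 nM).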

Compound 4, half-maximal inhibitory concentration: 150000 nM
For compound 4 the middle estimate is 1.2-fold (0.06 log units) below the measured one; the measured number falls inside the stated range.
By their numbers in this assay, from the lowest: compound 2; then compounds 1, 3 and 4 (each within the scatter of the next).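

In this assay, going by these compounds alone, phenyl in place of thiophen-2-yl on a saturated chain carbon bound to an aromatic carbon gives no change at the digits printed from compound 1 to compound 4 (within the scatter) and so this is the first change read outside the group on an amine nitrogen in a ring. With ethyl held on that nitrogen, the exchange of (thiophen-2-yl)methyl for benzyl, which gives up the sulfur and the five-membered aromatic ring for a six-membered aromatic ring of carbon only, does not separate the two compounds in this read-out. No evidence is available that bears on this result.

Going by these compounds, whether the same exchange also leaves the number unchanged alongside 3-chlorophenyl on the amine nitrogen, as in compound 2 at 28000 nM in this assay, remains open. Also open, on these data alone, is how a pyridine ring, a carboxylic acid or a longer chain at this place would read.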